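A few compounds are considered here, and "the series" means these few. Any claim that something is new, unique, unknown or untested is made for them only; others in the source may bear on it.

Within the data shown here, compound 1 `N#Cc1c(Cl)c(Cl)c(C(C(=O)c2ccc(Cl)cc2)=C2NCCN2)c(C#N)c1Cl` is the first of three measured compounds; in a functional assay on A-431 cells (Homo sapiens) for antiproliferative activity, read by MTT assay (on this read-out lower numbers stand for stronger inhibition and higher numbers for weaker inhibition), compound 1 gives 1.5 ug/mL. Compound 3 `Cc1ccc(C(=O)C(=C2NCCN2)c2c(Cl)c(Cl)c(C#N)c(Cl)c2C#N)cc1` keeps the core of compound 1 and differs from it only by methyl in place of chloro on an aromatic carbon. In this assay compound 3 gives 4.1 ug/mL, so that this change brought a 2.7-fold higher number from compound 1 to compound 3 (0.44 log units; beyond the scatter). Compound 2 `N#Cc1c(F)c(Cl)c(C(C(=O)c2ccc(Cl)cc2)=C2NCCN2)c(C#N)c1F` carries a different core; how the cores of compound 2 and compound 1 differ is not broken down here. In this assay compound 2 gives 1.8 ug/mL, and the two values of compound 2 and compound 1 lie within the usual scatter of each other.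

Compound 4 `Cc1ccc(C(=O)C(=C2NCCN2)c2c(Cl)c(F)c(C#N)c(F)c2C#N)cc1` has not yet been measured. It differs from compound 2 by methyl in place of chloro on an aromatic carbon, the same change, made at the same place, as that from compound 1 to compound 3. On the assumption that this change acts on the core of compound 2 as it did on the core of compound 1, where it gave a 2.7-fold higher number from compound 1 to compound 3 (0.44 log units; beyond the scatter), the step from compound 2 to compound 4 is expected to be a 2.5-fold higher number from compound 2 to compound 4 (0.40 log units; beyond the scatter). Accordingly, in this assay compound 4 is estimated to give 4.5 ug/mL, with a range from 2.5 ug/mL to 9 ug/mL allowing for the scatter of such measurements and for the single precedent on which this expectation rests.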

Compound 4, half-maximal inhibitory concentration: 1.7 ug/mL
For compound 4 the middle estimate is 2.6-fold (0.42 log units) above the measured one; measured number outside the range, below it.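

In this assay, putting methyl in place of chloro on the core of compound 2, that is, going from 4-chlorophenyl to 4-methylphenyl, gave a 1.1-fold lower number from compound 2 to compound 4 (0.02 log units; within the scatter), so on this core the change leaves no difference that can be told from the scatter. The change therefore did not carry over from one core to the other with the size it had first shown, and the two steps differ by more than their scatter allows: the same change on two cores in this assay, a 2.7-fold higher number (0.44 log units; beyond the scatter) from compound 1 to compound 3 and a 1.1-fold lower number (0.02 log units; within the scatter) from compound 2 to compound 4, 2.9-fold (0.46 log units) apart, beyond the scatter of two such steps. Among these compounds, this shows that, in this series, the result of the change depends on the core it is made on, but with only two pairs in a single assay it does not show which difference between the cores is responsible, nor which step is the more usual one.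

Going by these compounds, it remains open whether a third core would follow the pair on the core of compound 1 or the pair on the core of compound 2. On these data alone, it is also open whether a methoxy group or an amine on the same aromatic carbon would depend on the core in the same way.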